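A few compounds are considered here, and "the series" means these few. Any claim that something is new, unique, unknown or untested is made for them only; others in the source may bear on it.

Compound 1 `CC(C)N1CCN(Cc2csc(N)c2C(=O)c2ccc(Cl)cc2)CC1`: in a functional assay on CHO cells with adenosine receptor A1 (Homo sapiens) as the target, read by cAMP accumulation and immunoassay, with a stated time of 6 min, tested at 0.1 uM (a higher number here means a weaker effect of the compound at the concentration tested, a lower number a stronger effect), compound 1 gives 3.6%.
Compound 2 `Nc1scc(CN2CCN(c3ccc(Cl)cc3Cl)CC2)c1C(=O)c1ccc(Cl)cc1`: in this assay compound 2 gives -11%.

Among these two numbers, compound 2 stands lowest; its nearest neighbour is compound 1, and the step of a number 14.6 percentage points lower from compound 1 to compound 2 (beyond the scatter) lies beyond the usual scatter. Compound 3 `Nc1scc(CN2CCN(c3cccc(Cl)c3Cl)CC2)c1C(=O)c1ccc(Cl)cc1` is the next compound: 2,3-dichlorophenyl in place of 2,4-dichlorophenyl on an amine nitrogen in a ring. Among the compounds with values here, only one measured step exists, a number 14.6 percentage points lower from compound 1 to compound 2 (beyond the scatter), and it concerns a different change, the swap of an isopropyl for a 2,4-dichlorophenyl on the ring nitrogen; no measured pair shows what shifting a chlorine on that dichlorophenyl does. That step therefore gives little guidance, and the change from compound 2 to compound 3 keeps the same atoms in a closely related arrangement. The expectation is a step of a number 5 percentage points higher from compound 2 to compound 3 (within the scatter) that stays within the scatter. Compound 3 is therefore estimated at -6% in this assay, with a range from -25% to 14%.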

Compound 3, a percentage reported as activity, at one concentration (the size of the read-out at that concentration, not a potency): 3.2%
Beside the measured number, compound 3's estimate is 9.2 percentage points below it; the measured number falls inside the stated range.
By their numbers in this assay, from the lowest: compound 2; then compounds 3 and 1 (each within the scatter of the next).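

In this assay, the 2,3-dichlorophenyl and 2,4-dichlorophenyl groups hold the same atoms, yet the swap gives a number 14.2 percentage points higher from compound 2 to compound 3 (beyond the scatter) and shows that the read-out depends on how the chlorines are arranged on this ring, not only on which kind of group sits on the ring nitrogen. Replacing isopropyl with a dichlorophenyl group therefore has no single outcome, since the 2,3-dichlorophenyl change gives a number 0.4 percentage points lower from compound 1 to compound 3 (within the scatter) and leaves no lower number of the kind seen with the 2,4-dichlorophenyl group in compound 2. Nothing available here explains why the arrangement matters.

The compounds shown leave open how a phenyl ring with no chlorine or with a single chlorine would read at this position. They also leave open whether a methoxy group or a fluorine in place of these chlorines would follow the same pattern.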